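A Fluorophenyl Swap on the Ring Nitrogen

The source may report more compounds than this note shows. Statements on the series, on what has been measured and on what is new or still open speak of the compounds shown alone.

Compound 1 `COc1ccccc1N1C(=O)CSC1c1cc(F)cc(C(=O)O)c1` gives only a limit in a functional assay on HOS-TE85 cells (Homo sapiens) for inhibition, read by CCK-8 assay, with a stated time of 72 h (on this read-out higher numbers stand for weaker inhibition and lower numbers for stronger inhibition), namely > 1000 nM. For the measured compounds named here, compound 2 `COc1ccc(C)cc1N1C(=O)CSC1c1cccc(C(=O)NCCCCc2ccccc2)c1` is the single compound with a number in this assay, where compound 2 gives 300 nM. Going by the values given here, the one further value shown sits at the limit of > 1000 nM in this assay, at which 1 of the 2 values shown sits. Among the compounds with values here, compound 1 and compound 2 differ in two places, so their values define no step. Compound 3 `O=C(NCCCCc1ccccc1)c1cccc(C2SCC(=O)N2c2cccc(F)c2)c1` has not yet been measured; it differs from compound 2 in one place (3-fluorophenyl in place of 2-methoxy-5-methylphenyl on an amide-type nitrogen in a ring). The change is expected to be modest, toward weaker inhibition a 1.7-fold higher number from compound 2 to compound 3 (0.22 log units; within the scatter). For compound 3 the expected value in this assay is 500 nM, between 150 nM and 2000 nM.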

Compound 3, half-maximal inhibitory concentration: 32.4 nM
Compound 3: the middle estimate sits 15-fold (1.19 log units) above what was measured; measured number outside the range, below it.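

For the compounds shown here, on the amide-type nitrogen in a ring, the choice of aryl group clearly counts in this assay: 3-fluorophenyl in place of 2-methoxy-5-methylphenyl gives a 9.3-fold lower number from compound 2 to compound 3 (0.97 log units; beyond the scatter), the only step here that can be read. The earlier compounds shown here offered no such comparison at this position. No measurement shown here accounts for the size of this step.

From the compounds shown here alone, whether it follows from adding the fluorine or from losing the methoxy and methyl groups remains open. So does how an unsubstituted phenyl or a 3-chlorophenyl would read on this nitrogen.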